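Swapping a Difluorobenzyl for a Phenylethyl on the Core

This account rests on a few compounds, and the source may have more. Where it says the series, first, only, none or still open, it means among the compounds named here.

Compound 3 `COc1ccc2[nH]c3c(c2c1)CCNC31CCN(Cc2ccc(F)cc2F)CC1` gives 2000 nM in an assay on FRT cells for positive allosteric modulation of Cystic fibrosis transmembrane conductance regulator variant N1303K (Homo sapiens), in the presence of a further agent that is not named here (a lower number here means that less compound is needed, a higher number that more compound is needed for the effect), the lowest of the three numbers shown. Compound 2 `COc1ccc2[nH]c3c(c2c1)CCNC31CCN(Cc2cc(F)cc(Cl)c2)CC1` gives 2500 nM, and the step of a 1.3-fold lower number from compound 2 to compound 3 (0.10 log units; within the scatter) lies within the scatter. Compound 1 `COc1ccc2[nH]c3c(c2c1)CCNC31CCN(Cc2ccc([N+](=O)[O-])cc2F)CC1` gives 5900 nM; the steps of a 3.0-fold lower number from compound 1 to compound 3 (0.47 log units; beyond the scatter) and a 2.4-fold lower number from compound 1 to compound 2 (0.37 log units; beyond the scatter) are both beyond the scatter. Compound 4 `COc1ccc2[nH]c3c(c2c1)CCNC31CCN(C(C)c2ccccc2)CC1` differs from compound 3 by 1-phenylethyl in place of 2,4-difluorobenzyl on an amine nitrogen in a ring. All measured steps alter only the groups on the aromatic ring, and the largest of them came from replacing nitro; none covers a change of the group joining that ring to the nitrogen. Among the measured compounds shown here, with no direct precedent, only a modest rise is expected. Compound 4 is therefore estimated at 3500 nM, within 1200 nM to 10000 nM, the expected step being a 1.8-fold higher number from compound 3 to compound 4 (0.24 log units; within the scatter).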

Compound 4, half-maximal effective concentration: 20000 nM
For compound 4 the middle estimate is 5.7-fold (0.76 log units) below the measured one, outside the stated range (above it).
By their numbers in this assay, from the lowest: compounds 3 and 2 (each within the scatter of the next); then compound 1; then compound 4.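

Unlike the earlier swaps of groups on the aromatic ring, changing the group on the ring amine nitrogen to 1-phenylethyl gives a much larger rise in this assay: a 10-fold higher number from compound 3 to compound 4 (1.00 log units; beyond the scatter) and an 8.0-fold higher number from compound 2 to compound 4 (0.90 log units; beyond the scatter). Both steps exceed every step among compound 1, compound 2 and compound 3, so this position is less tolerant than those compounds suggested. Nothing here explains the rise.

Compound 4 both branches the link and drops the halogens, leaving their shares unresolved. A plain benzyl or a 1-(2,4-difluorophenyl)ethyl group would separate them.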